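This account rests on a few compounds, and the source may have more. Where it says the series, first, only, none or still open, it means among the compounds named here.

Compound 2 `CCCCNc1nc(C)nc2c1nnn2-c1ccc(C(C)C)cc1Br` is one of two compounds built on the same fused core and tested in an in vitro assay on 293-EBNA cells for binding affinity to corticotropin-releasing factor receptor 1 (Homo sapiens); on this read-out lower numbers stand for stronger inhibition and higher numbers for weaker inhibition. In this assay compound 2 gives 69.6 nM, the higher of the two numbers; compound 1 `COCC(COC)Nc1nc(C)nc2c1nnn2-c1ccc(C(C)C)cc1Br` gives 10.3 nM. Among the measured compounds shown here, the one change between them, butyl in place of 2-methoxy-1-(methoxymethyl)ethyl on the ring nitrogen, brought a 6.8-fold higher number from compound 1 to compound 2 (0.83 log units; beyond the scatter).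

Compound 3 `CCOCC(COCC)Oc1nc(C)nc2c1nnn2-c1ccc(C(C)C)cc1Br` changes compound 2 at one place: a group of 10 heavy atoms (7 carbon, 3 oxygen; no ring) in place of a group of 5 heavy atoms (4 carbon, 1 nitrogen; no ring), on an aromatic carbon. The entering group resembles the branched, two-ether side chain of compound 1 in shape, but it is joined to the core through oxygen, so the hydrogen-bond donor present in both measured compounds is gone. For the measured compounds named here, only one measured step bears on this, the one from compound 1 to compound 2, and it was modest. Returning to a branched two-ether chain is therefore expected to bring the number back down, but the untested switch from nitrogen to oxygen makes the size uncertain. A step of a 3.5-fold lower number from compound 2 to compound 3 (0.54 log units; beyond the scatter) is expected, and compound 3 is estimated at 20 nM, within a range from 5 nM to 80 nM.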

Compound 3, inhibition constant: 39.7 nM
Estimate against measurement, compound 3: 2.0-fold (0.30 log units) below; low and high end bracket the measured number.
By their numbers in this assay, from the lowest: compound 1; then compounds 3 and 2 (each within the scatter of the next).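

In this assay, the butylamino group and the larger group of compound 3, which carries no hydrogen-bond donor, cannot be told apart, with a 1.8-fold lower number from compound 2 to compound 3 (0.24 log units; within the scatter). A branched chain with ether oxygens is therefore not enough on its own to match compound 1, as a clear gap remains, with a 3.9-fold higher number from compound 1 to compound 3 (0.59 log units; beyond the scatter). Nothing measured here gives a reason for this difference between two similar-looking branched groups.

Compound 3 differs from compound 1 in two features within the one changed group: oxygen instead of nitrogen joins the chain to the core, and the chain ends in ethoxy rather than methoxy groups, so the compounds shown cannot say which feature matters or whether both do. Also open, from the compounds shown here alone, is how a butoxy group would compare with butylamino at this aromatic carbon, and how a longer chain such as hexylamino or a ring such as morpholine would behave there.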